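This account rests on a few compounds, and the source may have more. Where it says the series, first, only, none or still open, it means among the compounds named here.

Compound 3 `Cc1cccc2sc(NC(=O)CCN3CCN(C4CCCCC4)CC3)nc12` is the strongest inhibitor of the three compounds measured in an assay on membranes from brain for displacement of a labelled ligand from Sigma non-opioid intracellular receptor 1 (Cavia porcellus), read by scintillation counting, with a stated time of 120 min (a higher number here means a weaker inhibitor, a lower number a stronger inhibitor), where compound 3 gives 24 nM. The two comparison compounds share its core and differ only in the group on the amine nitrogen of the six-membered ring with two nitrogens: compound 1 `Cc1cccc2sc(NC(=O)CCN3CCN(C(C)(C)C)CC3)nc12` gives 147 nM and compound 2 `Cc1cccc2sc(NC(=O)CCN3CCN(CC4CCCO4)CC3)nc12` gives 109 nM. Both steps to compound 3 were modest but clear, a 6.1-fold lower number from compound 1 to compound 3 (0.79 log units; beyond the scatter) and a 4.5-fold lower number from compound 2 to compound 3 (0.66 log units; beyond the scatter), while the step of a 1.3-fold lower number from compound 1 to compound 2 (0.13 log units; within the scatter) was not.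

Compound 4 `Cc1cccc2sc(NC(=O)CCN3CCN(C4CCN(C)CC4)CC3)nc12` is the next compound to be measured. It differs from compound 3 in one place: 1-methylpiperidin-4-yl in place of cyclohexyl on an amine nitrogen in a ring. The measured steps bear on this only loosely. They show that a cyclohexyl on that nitrogen gave a lower number than the two other groups tried, and that compound 2, whose group also carries one hetero atom, gave a higher number than compound 3. For the measured compounds named here, no measured step shows what placing a nitrogen inside the ring itself does. The expectation is therefore a modest loss, a step of a 2.9-fold higher number from compound 3 to compound 4 (0.46 log units; beyond the scatter), with wide uncertainty. Compound 4 is thus estimated at 70 nM, with a likely range from 20 nM to 250 nM.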

Compound 4, inhibition constant: 6000 nM
For compound 4 the middle estimate is 86-fold (1.93 log units) below the measured one, and the stated range ends below it.
By their numbers in this assay, from the lowest: compound 3; then compounds 2 and 1 (each within the scatter of the next); then compound 4.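

In this assay this position proves far less tolerant than the first three compounds suggested: 1-methylpiperidin-4-yl in place of cyclohexyl, a swap that keeps a six-membered ring, gives a 250-fold higher number from compound 3 to compound 4 (2.40 log units; beyond the scatter) as the outcome. The new group also falls far behind the other two groups, with a 55-fold higher number from compound 2 to compound 4 (1.74 log units; beyond the scatter) and a 41-fold higher number from compound 1 to compound 4 (1.61 log units; beyond the scatter) making compound 4 the weakest of the four. Carrying one hetero atom does not by itself decide the outcome, as the group of compound 2 also has one and compound 2 stays much closer to compound 3.

Nothing measured here explains the drop. On these data alone, it remains open whether the ring nitrogen or its methyl matters more: piperidin-4-yl without the methyl, or oxan-4-yl with an oxygen in the ring, would help separate the two.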